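This account rests on a few compounds, and the source may have more. Where it says the series, first, only, none or still open, it means among the compounds named here.

Working notes on the series.

Compound 1 `Cc1cc(NC(=O)Nc2cccc(F)c2)c2ccccc2n1` carries a fluoro group on the outer aromatic ring and in a physicochemical assay for solubility, at pH 7.4 (a higher number here means a more soluble compound, a lower number a less soluble compound), compound 1 gives 100 nM. Compound 2 `Cc1cc(NC(=O)Nc2cccc(C(F)(F)F)c2)c2ccccc2n1` differs only by trifluoromethyl in place of fluoro on an aromatic carbon; in this assay compound 2 gives 100 nM, so the step of no change at the digits printed from compound 1 to compound 2 (within the scatter) shows no change beyond the scatter, and compound 2 stands level with compound 1 at the digits printed.

Compound 3 `Cc1cc(NC(=O)Nc2cccc(OC(F)(F)F)c2)c2ccccc2n1` is the next point in the set and is not yet measured in this assay. It differs from compound 2 as follows: trifluoromethoxy in place of trifluoromethyl on an aromatic carbon. Among the compounds with values here, the only measured step that bears on it is the one from compound 1 to compound 2, where a change of group on the same aromatic carbon left solubility unmoved within the scatter. On that basis no step beyond the scatter is expected here either, and the expected step of no change at the digits printed from compound 2 to compound 3 (within the scatter) is therefore set close to zero. Compound 3 is estimated at 100 nM, with a range from 40 nM to 250 nM, pending the measurement.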

Compound 3, solubility: 600 nM
For compound 3 the middle estimate is 6.0-fold (0.78 log units) below the measured one; the measured number lies above the stated range.
By their numbers in this assay, from the lowest: compounds 1 and 2 (each within the scatter of the next); then compound 3.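

The aromatic carbon that showed nothing on going from fluoro to trifluoromethyl does respond in this assay: trifluoromethoxy in place of trifluoromethyl brings a 6.0-fold higher number from compound 2 to compound 3 (0.78 log units; beyond the scatter), and trifluoromethoxy in place of fluoro brings a 6.0-fold higher number from compound 1 to compound 3 (0.78 log units; beyond the scatter). The position is therefore not indifferent to what it carries: the earlier result, no change at the digits printed from compound 1 to compound 2 (within the scatter), holds for that pair of groups and does not extend to trifluoromethoxy. The entering group has one more heavy atom than trifluoromethyl, an oxygen counted as a hydrogen-bond acceptor, but no measurement in hand says what lies behind the higher number.

The compounds shown leave open whether this step belongs to trifluoromethoxy alone or extends to other oxygen-linked groups, such as methoxy or a longer ether chain, on the same aromatic carbon, and how an amine would read there. They also leave open whether the same exchange gives a similar step at other carbons of this ring or on a changed core.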